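A Furan Replaces Fluorophenyl on the Carbonyl

A few compounds are considered here, and "the series" means these few. Any claim that something is new, unique, unknown or untested is made for them only; others in the source may bear on it.

Compound 1 `COc1cc(-c2nnc3n2NC(c2ccco2)C(C(=O)c2ccccc2F)S3)cc(OC)c1OC` gives 94800 nM in a functional assay on MCF7 cells (Homo sapiens) for cytotoxicity, read by MTT assay, with a stated time of 48 h; on this read-out higher numbers stand for weaker inhibition and lower numbers for stronger inhibition. In this assay compound 2 `COc1cc(-c2nnc3n2NC(c2ccco2)C(C(=O)c2ccc(F)cc2)S3)cc(OC)c1OC` reaches the assay's limit of > 100000 nM, which is a limit and not a number. Compound 3 `COc1cc(-c2nnc3n2NC(c2cccs2)C(C(=O)c2ccc(Cl)cc2)S3)cc(OC)c1OC` gives 42800 nM in this assay. For the measured compounds named here, the single step measured in one place, an at least 1.0-fold higher number from compound 1 to compound 2 (0.02 log units; that floor lies within the scatter), lies within the scatter. Compound 4 `COc1cc(-c2nnc3n2NC(c2ccco2)C(C(=O)c2ccco2)S3)cc(OC)c1OC` differs from compound 2 by furan-2-yl in place of 4-fluorophenyl on a carbonyl carbon. Going by the values given here, no measured step exchanges a six-membered ring for a five-membered one on the carbonyl carbon, so that earlier step offers little guidance, and all three measured values sit in the region of weak inhibition. A step of a number no higher from compound 2 to compound 4 (the limit leaves the size open) is therefore expected, within the scatter. The estimate for compound 4 is 100000 nM, ranging from 40000 nM to 250000 nM.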

Compound 4, half-maximal inhibitory concentration: > 100000 nM
Compound 4 gave a limit, no number; the forecaster's own chance of this, stated with the estimate: 50%; the middle value lies on the limit itself.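

In this assay compound 4 gives > 100000 nM, which is a limit and not a number. Furan-2-yl in place of 2-fluorophenyl gives an at least 1.0-fold higher number from compound 1 to compound 4 (0.02 log units; that floor lies within the scatter), so this five-membered ring on the carbonyl carbon shows no stronger inhibition than compound 1. The step between compound 2 and compound 4 cannot be read, and a second compound now sits at the same limit: the limit of > 100000 nM in this assay, at which 2 of the 4 values shown sit.

Going by these compounds, whether an amine or a carboxylic acid on this carbonyl carbon would give a value clear of the limit stays open. Compound 3, at 42800 nM, differs from the others in more than one place, so its value cannot be tied to any single change.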